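Trimming the hydrazone: phenyl to hydrogen

A few compounds are considered here, and "the series" means these few. Any claim that something is new, unique, unknown or untested is made for them only; others in the source may bear on it.

Measured so far:
compound 1, `Cc1ccc2[nH]c(=O)c(/C=N/c3ccccc3O)cc2c1`, 286000 nM
compound 2, `Cc1ccc2[nH]c(=O)c(/C=N/O)cc2c1`, 389000 nM
compound 3, `Cc1ccc2[nH]c(=O)c(/C=N/Nc3ccccc3)cc2c1`, 309000 nM

These three compounds share one core and differ only in the group hung on the double-bonded nitrogen. In a functional assay, read by spectrophotometry, with a stated time of 5 min (on this read-out lower numbers stand for stronger inhibition and higher numbers for weaker inhibition), compound 3 gives 309000 nM, the second highest of the three numbers; its neighbours are close, with a 1.1-fold higher number from compound 1 to compound 3 (0.03 log units; within the scatter) and a 1.3-fold lower number from compound 2 to compound 3 (0.10 log units; within the scatter), so the three compounds cannot be told apart on this read-out. The step to be followed leads to compound 4, `Cc1ccc2[nH]c(=O)c(/C=N/N)cc2c1`, with the change (hydrogen in place of phenyl on an amine nitrogen).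

The steps measured so far all bear on this change, since each swaps the group on the same nitrogen: a 1.4-fold higher number from compound 1 to compound 2 (0.13 log units; within the scatter), a 1.1-fold higher number from compound 1 to compound 3 (0.03 log units; within the scatter) and a 1.3-fold lower number from compound 2 to compound 3 (0.10 log units; within the scatter). None of them moved the number beyond the scatter, whether a hydroxy, a 2-hydroxyphenyl or an anilino sat there. Removing the phenyl from the anilino of compound 3 is therefore expected to leave the number where it is, with no step beyond the scatter in either direction, so that a 1.0-fold higher number from compound 3 to compound 4 (0.02 log units; within the scatter) is expected. Compound 4 is estimated at 320000 nM, within a range from 150000 nM to 700000 nM.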

Compound 4, half-maximal inhibitory concentration: 153000 nM
For compound 4 the middle estimate is 2.1-fold (0.32 log units) above the measured one, and the stated range covers the measured number.
By their numbers in this assay, from the lowest: compounds 4, 1, 3 and 2 (each within the scatter of the next, the first and the last beyond it).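

In this assay, within the data shown here, this is the first change on this nitrogen to move the number beyond the scatter: a 2.0-fold lower number from compound 3 to compound 4 (0.31 log units; beyond the scatter), and the swap of hydroxy for amino gives a 2.5-fold lower number from compound 2 to compound 4 (0.41 log units; beyond the scatter). The group here can therefore shift the read-out, if only modestly, but losing a ring does not account for the shift on its own: compound 2 also carries no ring on this nitrogen, and the ring-bearing compound 1 cannot be separated from compound 4, with a 1.9-fold lower number from compound 1 to compound 4 (0.27 log units; within the scatter). Nothing available explains why the amino group stands apart from hydroxy and anilino.

As far as these compounds go, what remains open is whether the gain depends on the bare amino group itself or would survive small additions to it, as in a methylamino, a dimethylamino or an acetamido group on the same nitrogen. A longer chain such as an aminoethyl group would test whether this position tolerates anything larger than amino without the number rising again toward that of compound 3.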